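This account rests on a few compounds, and the source may have more. Where it says the series, first, only, none or still open, it means among the compounds named here.

The measurements come from a physicochemical assay for lipophilicity, read by HPLC, in phosphate buffer, measured as chromatographic lipophilicity, at pH 7.4; on this read-out lower numbers stand for lower lipophilicity and higher numbers for higher lipophilicity. Of the compounds shown here, three have numbers so far. Compound 1, `Cc1cc(C)cc(NC(=O)COc2cc(C)nc3ccc(OC(F)(F)F)cc23)c1`, gives the highest reading in this assay at 6.79. Compound 2, `COc1ccc2nc(C)cc(NCC(=O)Nc3cc(C)cc(C)c3)c2c1`, gives the lowest reading in this assay at 3.59. Compound 3, `COc1ccc2nc(C)cc(OCC(=O)Nc3cc(C)ccc3C)c2c1`, sits between the two: in this assay compound 3 gives 5.05, the second highest of the three numbers, a value that lies beyond the scatter both from the lower number of compound 2 and from the higher number of compound 1. Within the data shown here, no two of these three compounds differ from each other in a single place, so no step between measured compounds can be counted here.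

Compound 4, `COc1ccc2nc(C)cc(OCC(=O)Nc3ccccn3)c2c1`, has not yet been measured in this assay. It differs from compound 3 in one place: pyridin-2-yl in place of 2,5-dimethylphenyl on an amide-type nitrogen. The group that leaves carries two methyls on a ring of carbon only, while the group that enters is smaller and brings one hydrogen-bond acceptor into the ring. On the numbers shown, a change of this kind is expected to lower the reading in this assay well beyond the scatter, and the step from compound 3 to compound 4 is estimated as a number 1.85 log units lower from compound 3 to compound 4 (beyond the scatter). Compound 4 is therefore expected to come in near 3.2, with a likely range from 2.5 to 4.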

Compound 4, distribution coefficient: 3.49
Beside the measured number, compound 4's estimate is 0.29 log units below it; measured number inside the range.
By their numbers in this assay, from the lowest: compounds 4 and 2 (each within the scatter of the next); then compound 3; then compound 1.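

Among these compounds, this is the first comparison in which only one place changes, so the effect of that place can be read directly. In this assay, putting pyridin-2-yl in place of 2,5-dimethylphenyl on the amide-type nitrogen gives a number 1.56 log units lower from compound 3 to compound 4 (beyond the scatter), a large step with the rest of the structure held constant. The group on this nitrogen therefore matters to the reading in its own right, which the three earlier compounds could not show because each of them differs from the others in more than one place. Among the compounds shown here, nothing available explains why this swap moves the number so far.

The change removes the two methyls and brings a nitrogen into the ring at the same time, so the compounds shown do not divide the step between these two differences; a plain phenyl or a 2-methylphenyl group on the same nitrogen would separate them. On these data alone, whether the same swap would give a step of similar size on the core of compound 1, or with the linking oxygen replaced by the amine nitrogen of compound 2, also remains open.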